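Swapping a pyrazolylmethyl arm for methoxy on the shared core

The source may report more compounds than this note shows. Statements on the series, on what has been measured and on what is new or still open speak of the compounds shown alone.

The series is followed in a functional assay on CHO cells for agonist activity at Melanocortin receptor 4 (Homo sapiens), read by a luciferase reporter, with a stated time of 4 h; a higher number here means that more compound is needed for the effect, a lower number that less compound is needed. Compound 1, with structure `CCn1nc(CC2(OC)C(=O)N(CC(=O)N(c3ccc(OC)cc3)C(C)C)C=CN(c3ccccc3)C2=O)c2ccccc21`, gives 31600 nM; > 30000 nM (2 entries); the several entries for compound 1 in this assay are gathered in the several entries of compound 1 in this assay, 31600 nM; > 30000 nM (2 entries). Going by the values given here, compound 2, with structure `COc1ccc(N(C(=O)CN2C=CN(c3ccccc3)C(=O)C(Cc3cc[nH]n3)(Cc3n[nH]c4ccccc34)C2=O)C(C)C)cc1`, is the only compound with a single number in this assay, and in this assay compound 2 gives 1050 nM; a further entry for compound 2 carries no number. Among the compounds with values here, no step between measured compounds in this assay is available, so the next compound is judged from compound 2 alone.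

Compound 3, with structure `COc1ccc(N(C(=O)CN2C=CN(c3ccccc3)C(=O)C(Cc3n[nH]c4ccccc34)(OC)C2=O)C(C)C)cc1`, is the not yet measured member. The change from compound 2 to compound 3 is methoxy in place of (1H-pyrazol-3-yl)methyl on a saturated ring carbon, the group being removed leaving one five-membered aromatic ring and one hydrogen-bond donor, and the entering group bringing no ring.

For compound 3 the expectation is a loss of agonist potency that goes beyond the usual scatter, an estimated step of a 7.6-fold higher number from compound 2 to compound 3 (0.88 log units; beyond the scatter) in this assay. Compound 3 is therefore estimated at 8000 nM, with a plausible range from 2000 nM to 40000 nM.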

Compound 3, half-maximal effective concentration: 166 nM
The estimate for compound 3 lay 48-fold (1.68 log units) above the measured number, and the stated range ends above it.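

In this assay, the (1H-pyrazol-3-yl)methyl arm on this saturated ring carbon proves not to be required for agonist potency: putting methoxy in its place gives a 6.3-fold lower number from compound 2 to compound 3 (0.80 log units; beyond the scatter) and still leaves a compound that acts at a lower concentration. The smaller group, with no ring and no hydrogen-bond donor, is thus better tolerated here than the larger arm, so the five-membered aromatic ring and its donor bring no gain at this carbon in this pair. Methoxy at this carbon does not secure potency by itself, however, for compound 1 carries the same methoxy and differs from compound 3 in one place, an added ethyl group elsewhere on the molecule, and one of its entries is a limit of the assay: the several entries of compound 1 in this assay, 31600 nM; > 30000 nM (2 entries).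

With only two groups compared on this carbon, the compounds shown cannot tell whether the result reflects something particular to methoxy or simply the removal of the larger arm. Going by these compounds, how a hydroxyl, an ethoxy or a plain methyl group would behave at this carbon remains open, as does whether a primary amine would be accepted there.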